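The source may report more compounds than this note shows. Statements on the series, on what has been measured and on what is new or still open speak of the compounds shown alone.

Measured so far in an assay on Vas deferens with Adrenergic receptor alpha-1 (Rattus norvegicus) as the target; a higher number here means weaker binding, a lower number tighter binding:
- compound 1 `COc1cccc(OC)c1OCCNC[C@@H]1CSc2ccccc2C1=O` gives 1.29 nM
- compound 2 `COc1cccc(OC)c1OCCNC[C@@H]1COc2ccccc2[C@@H]1O` gives 60.3 nM

Compound 2 stands at the higher of the two numbers; its gap to compound 1 lies beyond the scatter. Compound 3 `COc1cccc(OC)c1OCCNC[C@@H]1COc2ccccc2[C@H]1O` is its epimer: the two compounds have the same atoms and bonds and differ only in configuration as drawn: 1 of 2 stereo elements differ; a stereocentre at a saturated ring carbon is drawn R in compound 2 and S in compound 3. For the measured compounds named here, no measured pair shows what such a change does, so the direction is open. Since compound 2 sits at the top of the two numbers, the step from compound 2 to compound 3 is expected to be small, a 2.0-fold lower number from compound 2 to compound 3 (0.30 log units; within the scatter), with room either way. Compound 3 is estimated at 30 nM, in the range 6 nM to 150 nM.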

Compound 3, dissociation constant: 46.8 nM
The estimate for compound 3 lay 1.6-fold (0.19 log units) below the measured number, within the range that was stated.
By their numbers in this assay, from the lowest: compound 1; then compounds 3 and 2 (each within the scatter of the next).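

In this assay, redrawing the stereocentre at a saturated ring carbon from R to S gives a 1.3-fold lower number from compound 2 to compound 3 (0.11 log units; within the scatter). For the compounds shown here, this is the first reading of a configuration change, and at this position it separates the two compounds by no more than the scatter. Going by these compounds alone, the reading is direct because only one thing distinguishes the pair: the fact that compounds 2 and 3 differ only in the configuration as drawn.

On these data alone, whether an amine or a methoxy group at this ring carbon would behave the same way stays open. As far as these compounds go, the effect of inverting the other stereocentre also stays open.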